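Swapping an Aryl Ether for an Aryl Thioether

A few compounds are considered here, and "the series" means these few. Any claim that something is new, unique, unknown or untested is made for them only; others in the source may bear on it.

Measured compounds:
compound 1, `Nc1cc(N)c2nc(-c3ccccc3)c(Oc3ccc(Cl)c(Cl)c3)nc2c1`: < 100000 nM
compound 2, `CCOC(=O)[C@H](CCC(=O)O)NC(=O)c1ccc(CNc2nc3cc(N)cc(N)c3nc2-c2ccccc2)cc1`: < 100000 nM

In a functional assay on CAKI-1 cells (Homo sapiens) for inhibition, read by sulforhodamine B assay, with a stated time of 48 h (a higher number here means a weaker inhibitor of growth, a lower number a stronger inhibitor of growth), compound 1 gives < 100000 nM, which is a limit of the assay rather than a number. Compound 2 gives < 100000 nM in this assay, again only a limit. Compound 1 therefore has no definite position among the numbers shown: the limit of < 100000 nM in this assay, at which 2 of the 2 values shown sit. For the measured compounds named here, no measured step exists between compound 1 and compound 2, which differ in more than one place.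

Compound 3, `COc1ccc(Sc2nc3cc(N)cc(N)c3nc2-c2ccccc2)cc1`, is not yet measured. It differs from compound 1 in one place: (4-methoxyphenyl)sulfanyl in place of 3,4-dichlorophenoxy on an aromatic carbon. Going by the values given here, no measured pair shows what such a swap does here. Without such a reference, the step from compound 1 to compound 3 is expected to remain within the usual scatter, with no direction favoured, a step that the limit leaves unreadable from compound 1 to compound 3. Compound 3 is accordingly estimated at 30000 nM in this assay, between 5000 nM and 100000 nM, and it may well again be reported only as a limit.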

Compound 3, concentration for total growth inhibition: 52500 nM
Beside the measured number, compound 3's estimate is 1.8-fold (0.24 log units) below it; low and high end bracket the measured number.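

No step from compound 1 to compound 3 can be read, because compound 1 carries only a limit and not a number: the limit of < 100000 nM in this assay, at which 2 of the 3 values shown sit.

The compounds shown leave open whether (4-methoxyphenyl)sulfanyl in place of 3,4-dichlorophenoxy strengthens growth inhibition, weakens it or leaves it unchanged.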